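Replacing the Hydroxy Group on the Oxazolidinone Side Chain

The source may report more compounds than this note shows. Statements on the series, on what has been measured and on what is new or still open speak of the compounds shown alone.

Compound 1 `CCn1ccc(N2C[C@H](CO)OC2=O)c1`: 3 nM
Compound 2 `C=CCn1ccc(N2C[C@H](CO)OC2=O)c1`: 350 nM
Compound 3 `Cn1ccc(N2C[C@H](CN=[N+]=[N-])OC2=O)c1`: 200 nM

Of the compounds shown here, three sharing one core have been measured in an assay for inhibition of Amine oxidase [flavin-containing] A (Bos taurus), read by fluorescence, with a stated time of 30 min; on this read-out lower numbers stand for stronger inhibition and higher numbers for weaker inhibition. Compound 1 gives 3 nM and stands lowest of the three numbers; its nearest neighbour is compound 3 at 200 nM, and the furthest is compound 2 at 350 nM.

Among the measured compounds shown here, the only single-point step among them, a 120-fold higher number from compound 1 to compound 2 (2.07 log units; beyond the scatter), concerns the group on the aromatic nitrogen and leaves the side chain untouched, so it says nothing direct about the change now considered. Compound 4 `CCn1ccc(N2C[C@H](CNC)OC2=O)c1` differs from compound 1 by methylamino in place of hydroxy on a saturated chain carbon bound to a saturated ring carbon. For the measured compounds named here, compound 3 carries a different substituent at that same side-chain position, but it also differs in the group on the aromatic nitrogen, so its pair with compound 1 shows only that the two values differ.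

Going by the values given here, with no clean precedent for this change, the expectation for compound 4 rests on the two values alone: an estimated step of a 50-fold higher number from compound 1 to compound 4 (1.70 log units; beyond the scatter), towards a higher number. Compound 4 is therefore expected to give about 150 nM in this assay, within a range from 15 nM to 1500 nM.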

Compound 4, inhibition constant: 80 nM
For compound 4 the middle estimate is 1.9-fold (0.27 log units) above the measured one; the range from low to high includes it.
By their numbers in this assay, from the lowest: compound 1; then compound 4; then compounds 3 and 2 (each within the scatter of the next).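

In this assay, among the compounds shown here, the change from hydroxy to methylamino on a saturated chain carbon bound to a saturated ring carbon brings a 27-fold higher number from compound 1 to compound 4 (1.43 log units; beyond the scatter) and this is the first reading of this position in which nothing else in the molecule differs. The step is large even though both groups carry 1 hydrogen-bond donor, 1 hydrogen-bond acceptor and no net charge, so among these compounds matching those counts does not preserve the value of compound 1, and the side chain matters here as well as the group on the aromatic nitrogen. Nothing available here offers an independent measurement that would explain the size of this step.

Still open, from the compounds shown here alone, is whether the step follows from the nitrogen taking the place of the oxygen or from the added carbon, a question that a primary amine or a methoxy group at this position would address. Compound 3 differs from compound 4 in two places, so the effect of its side-chain group alone also remains unresolved, and a single replacement says little about how larger groups, such as a dimethylamino group, would behave here.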